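The compounds below may be only part of what the source reports. "The series", "measured", "known", "first", "only" and "open" are said of these compounds alone.

Compound 1 `COc1cccc(CNCCCNc2ccnc3cc(Cc4ccccc4)ccc23)c1O` — in a physicochemical assay for acid dissociation, it gives 9.47
Compound 2 `COc1ccc(F)cc1CNCCCNc1ccnc2cc(Oc3ccc(C(C)(C)C)cc3)ccc12` — in this assay compound 2 gives 9.28
Compound 3 `COc1ccc(F)cc1CNCCCNc1ccnc2cc(Cc3ccccc3)ccc12` — in this assay compound 3 gives 9.47

Compound 1 and compound 3 return the same number at the digits shown, and compound 2 sits close by: the step of a number 0.19 log units higher from compound 2 to compound 3 (within the scatter) stays within the scatter, as does no change at the digits printed from compound 1 to compound 3 (within the scatter). Across these three compounds, then, neither the change on the saturated chain carbon bound to the amine nitrogen nor the change on the aromatic carbon of the shared core moved the acid dissociation constant beyond the usual scatter.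

Compound 4 `COc1cccc(CNCCCNc2ccnc3cc(Cc4cccc(C(F)(F)F)c4)ccc23)c1O` has not yet been measured. It differs from compound 1 in one place: trifluoromethyl in place of hydrogen on an aromatic carbon. The step that bears most directly on it is a number 0.19 log units higher from compound 2 to compound 3 (within the scatter), where a far larger exchange at the same aromatic carbon left the number within the scatter. A trifluoromethyl group set on the benzyl ring, far from the amine, is therefore expected to do no more. Compound 4 is expected to give 9.42, with a likely range from 9.1 to 9.75. The expected step of a number 0.05 log units lower from compound 1 to compound 4 (within the scatter) is one within the scatter.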

Compound 4, acid dissociation constant: 9.47
Compound 4: the middle estimate sits 0.05 log units below what was measured, within the range that was stated.
By their numbers in this assay, from the lowest: compounds 2, 1, 3 and 4 (each within the scatter of the next).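

In this assay, among the compounds shown here, the exchange of benzyl for 3-(trifluoromethyl)benzyl gives no change at the digits printed from compound 1 to compound 4 (within the scatter), and this is the first reading of a change made on the benzyl ring itself. The earlier steps shown here exchanged the whole benzyl group for 4-(tert-butyl)phenoxy on an aromatic carbon of the shared core, or exchanged the aryl group on the saturated chain carbon; neither showed what a substituent on that ring does to this number, and here a group of 4 heavy atoms entering there stays within the scatter. Nothing given here accounts for this reading, so the result stands as an observation without an explanation.

The compounds shown leave open whether an amine or a carboxylic acid, set on the same aromatic carbon of the benzyl ring, would also stay within the scatter in this assay. They also leave open whether trifluoromethyl would read the same alongside 5-fluoro-2-methoxyphenyl, and whether a longer chain in the amine linker would shift the number.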